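A few compounds are considered here, and "the series" means these few. Any claim that something is new, unique, unknown or untested is made for them only; others in the source may bear on it.

Compound 2 `CC(O)C(=O)Nc1cc(Oc2ccc(Nc3nccc4[nH]cc(-c5ccc(F)cc5)c(=O)c34)cc2F)ccn1` stands highest of the two numbers in a functional assay on HT-29 cells (Homo sapiens) for antiproliferative activity, read by MTT assay, with a stated time of 72 h, tested at 10 uM; a lower number here means less inhibition, a higher number more inhibition at the concentration tested (going by the name of the read-out): compound 2 gives 47.8%, while compound 1 `O=C(Nc1cc(Oc2ccc(Nc3nccc4[nH]cc(-c5ccc(F)cc5)c(=O)c34)cc2F)ccn1)C1CC1` gives 25.5%, the step being a number 22.3 percentage points higher from compound 1 to compound 2 (beyond the scatter). Compound 3 `CCC(=O)Nc1cc(Oc2ccc(Nc3nccc4[nH]cc(-c5ccc(F)cc5)c(=O)c34)cc2F)ccn1` differs from compound 2 by hydrogen in place of hydroxy on a saturated chain carbon bound to a carbonyl carbon and a saturated chain carbon, so the side chain reads 1-hydroxyethyl to ethyl. Going by the values given here, only the step from compound 1 to compound 2 involves this hydroxy, and there its arrival came with a modest rise. Taking it away is expected to undo part of that rise, a number 15.8 percentage points lower from compound 2 to compound 3 (beyond the scatter). Compound 3 is therefore estimated at 32%, within a range from 18% to 48%.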

Compound 3, a percentage reported as inhibition, at one concentration (the size of the read-out at that concentration, not a potency): 68.7%
Compound 3: the middle estimate sits 36.7 percentage points below what was measured; measured number outside the range, above it.
By their numbers in this assay, from the lowest: compound 1; then compound 2; then compound 3.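

In this assay, taking the hydroxy away did not lower the number but raised it, a number 20.9 percentage points higher from compound 2 to compound 3 (beyond the scatter), so the higher value of 1-hydroxyethyl over cyclopropyl did not depend on the hydroxy. Plain ethyl in place of cyclopropyl on the carbonyl carbon gave the larger gain, a number 43.2 percentage points higher from compound 1 to compound 3 (beyond the scatter). Nothing measured here accounts for this order. Still open, on these data alone, is whether a longer chain such as propyl, or an amine on the ethyl chain, would keep this level. The order at other concentrations or in other cell lines is also unknown.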